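The source may hold more compounds than are shown below. What is called first, only, known or untested is meant among the compounds shown, and "the series" means these compounds.

Measured so far in an assay on isolated protein for binding affinity to Equilibrative nucleoside transporter 1 (Homo sapiens); a higher number here means a weaker inhibitor, a lower number a stronger inhibitor:
- compound 1 `CCCCCNc1ncnc2c1ncn2[C@@H]1O[C@H](CO)[C@@H](O)[C@H]1O` gives 13500 nM
- compound 2 `OC[C@H]1O[C@@H](n2cnc3c(SCC4CCCCC4)ncnc32)[C@H](O)[C@@H]1O` gives 1550 nM
- compound 3 `OC[C@H]1O[C@@H](n2cnc3c(CSc4ccccc4Br)ncnc32)[C@H](O)[C@@H]1O` gives 2400 nM

Compound 3 holds the second highest of the three numbers. Its gap to the nearest number is small: a 1.5-fold higher number from compound 2 to compound 3 (0.19 log units; within the scatter). Its gap to the furthest number is larger: a 5.6-fold lower number from compound 1 to compound 3 (0.75 log units; beyond the scatter).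

Compound 4 `OC[C@H]1O[C@@H](n2cnc3c(CSc4cccc(Cl)c4)ncnc32)[C@H](O)[C@@H]1O` differs from compound 3 by 3-chlorophenyl in place of 2-bromophenyl on a sulfur. Within the data shown here, no measured step exchanges one halogen-bearing phenyl for another. Among the measured compounds shown here, the only step touching this arm of the molecule is a 1.5-fold higher number from compound 2 to compound 3 (0.19 log units; within the scatter), which swaps the whole arm and still stays within the scatter. The remaining steps, an 8.7-fold lower number from compound 1 to compound 2 (0.94 log units; beyond the scatter) and a 5.6-fold lower number from compound 1 to compound 3 (0.75 log units; beyond the scatter), replace the pentylamino arm of compound 1 and carry no information on a halogen exchanged on the phenyl. On that basis no step beyond the scatter is expected in this assay. Compound 4 is therefore estimated at 2400 nM, with a range of 800 nM to 7200 nM. The expected step is no change at the digits printed from compound 3 to compound 4 (within the scatter).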

Compound 4, half-maximal inhibitory concentration: 282 nM
Compound 4: the middle estimate sits 8.5-fold (0.93 log units) above what was measured; measured number below the stated range.
By their numbers in this assay, from the lowest: compound 4; then compounds 2 and 3 (each within the scatter of the next); then compound 1.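

In this assay the substituted phenyl on the sulfur proves sensitive: 3-chlorophenyl in place of 2-bromophenyl gives an 8.5-fold lower number from compound 3 to compound 4 (0.93 log units; beyond the scatter) even though the two groups have the same heavy-atom count, the same ring and the same donor and acceptor counts. The arm can therefore carry more of the difference than compounds 2 and 3 suggested, with a 5.5-fold lower number from compound 2 to compound 4 (0.74 log units; beyond the scatter) and a 48-fold lower number from compound 1 to compound 4 (1.68 log units; beyond the scatter) placing compound 4 clearly apart from both earlier arms. No available evidence bears on the origin of this step.

The step changes the halogen and its ring position together, leaving their contributions unseparated; 3-bromophenyl and 2-chlorophenyl would divide them. Also open, going by these compounds, is how unsubstituted phenyl, 3-methoxyphenyl or 3-aminophenyl would compare on the same sulfur.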